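Benzyl to benzoylmethyl on the sulfur side chain

The source may hold more compounds than are shown below. What is called first, only, known or untested is meant among the compounds shown, and "the series" means these compounds.

- compound 1 `COc1ccc(-n2c(SCC(=O)c3ccccc3)nnc2-c2cc(OC)c(OC)c(OC)c2)cc1` gives 16200 nM
- compound 2 `COc1cc(-c2nnc(SCc3ccccc3)n2-c2ccc(N(C)C)cc2)cc(OC)c1OC` gives > 60000 nM (a limit, not a number)

Both entries come from a functional assay on HepG2 cells (Homo sapiens) for inhibition, read by MTT assay, with a stated time of 48 h (on this read-out higher numbers stand for weaker inhibition and lower numbers for stronger inhibition), and are the only data in hand. Compound 2 stands at a limit and has no number of its own. Compound 3 (`COc1cc(-c2nnc(SCC(=O)c3ccccc3)n2-c2ccc(N(C)C)cc2)cc(OC)c1OC`) is unmeasured and differs from compound 2 by one change (benzoyl in place of phenyl on a saturated chain carbon bound to a sulfur) in which benzoyl takes the place of phenyl on a saturated chain carbon bound to a sulfur. Going by the values given here, no measured pair isolates this change. Compound 1 also carries the (benzoylmethyl)sulfanyl group and gives 16200 nM in this assay and this value guides the expectation. A step towards stronger inhibition and beyond the scatter is expected, estimated as an at least 3.0-fold lower number from compound 2 to compound 3 (0.47 log units; beyond the scatter) in size. Compound 3 is estimated at 20000 nM (expected range 7000 nM to 55000 nM).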

Compound 3, half-maximal inhibitory concentration: 18900 nM
Compound 3: middle estimate off by 1.1-fold (0.02 log units), on the high side, within the range that was stated.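

In this assay, benzoyl in place of phenyl on a saturated chain carbon bound to a sulfur now has a measured pair behind it, giving an at least 3.1-fold lower number from compound 2 to compound 3 (0.50 log units; beyond the scatter). From the compounds shown here alone, the true size of this step stays unknown, since compound 2 stands at a limit and not at a number: the limit of > 60000 nM in this assay, at which 1 of the 3 values shown sits. With the (benzoylmethyl)sulfanyl group held in place, dimethylamino in place of methoxy on an aromatic carbon gives a 1.2-fold higher number from compound 1 to compound 3 (0.07 log units; within the scatter), so this read-out does not separate the two compounds.

Going by these compounds, whether the benzoyl step also holds on the core of compound 1 remains open. Also open, on these data alone, is how a longer chain between the sulfur and the carbonyl, or a carboxylic acid or an amine in place of the benzoyl group, would read in this assay.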